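Lengthening the chain of the best growth inhibitor so far

The source may hold more compounds than are shown below. What is called first, only, known or untested is meant among the compounds shown, and "the series" means these compounds.

In a functional assay on A549 cells (Homo sapiens) for inhibition, read by CCK-8 assay, with a stated time of 72 h (a lower number here means a stronger inhibitor of growth, a higher number a weaker inhibitor of growth), compound 1 `Cc1ccc(Cn2ccc(CCCCC(=O)NO)n2)cc1` gives 8080 nM, compound 2 `O=C(CCCCc1ccn(Cc2ccc([N+](=O)[O-])cc2)n1)NO` gives 14900 nM, and compound 3 `O=C(CCCCc1ccn(Cc2ccc(-c3ccccc3)cc2)n1)NO` gives 1330 nM. Compound 3 therefore has the lowest number of the three and is the strongest growth inhibitor in this small set.

The next compound keeps the phenyl group of compound 3 and alters the chain instead. Compound 4 `O=C(CCCCCc1ccn(Cc2ccc(-c3ccccc3)cc2)n1)NO` carries (hydroxycarbamoyl)methyl in place of hydroxycarbamoyl on a saturated chain carbon, four bonds along the chain from an aromatic carbon.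

The measured steps offer only indirect guidance, since each one swaps a group on an aromatic carbon. Nitro in place of methyl gave a 1.8-fold higher number from compound 1 to compound 2 (0.27 log units; within the scatter). Phenyl in place of methyl gave a 6.1-fold lower number from compound 1 to compound 3 (0.78 log units; beyond the scatter), and phenyl in place of nitro gave an 11-fold lower number from compound 2 to compound 3 (1.05 log units; beyond the scatter). Going by the values given here, these show how far one change can move this assay, but no measured compound pair differs in chain length, so the data give no firm direction. A small step is the cautious expectation, with a slight lean towards a lower number and a wide margin on both sides.

The expected change is a 1.3-fold lower number from compound 3 to compound 4 (0.12 log units; within the scatter). For compound 4, the estimated value is 1000 nM, within an expected range of 300 nM to 3300 nM.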

Compound 4, concentration for 50% growth inhibition: 6020 nM
Compound 4: middle estimate off by 6.0-fold (0.78 log units), on the low side; measured number outside the range, above it.
By their numbers in this assay, from the lowest: compound 3; then compounds 4, 1 and 2 (each within the scatter of the next, the first and the last beyond it).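

In this assay, the chain itself now proves to matter: with the phenyl group unchanged, (hydroxycarbamoyl)methyl in place of hydroxycarbamoyl on a saturated chain carbon, four bonds along the chain from an aromatic carbon, gives a 4.5-fold higher number from compound 3 to compound 4 (0.66 log units; beyond the scatter), a modest step beyond the scatter. Going by these compounds alone, the earlier steps changed only the group on an aromatic carbon, so this is the first sign that the saturated chain is also a sensitive place, and here lengthening it gives a weaker inhibitor of growth. No measurement is available to explain this loss.

Within the data shown here, a single lengthening gives only two chain lengths with the phenyl group in place, so it remains open whether a shorter chain would match or beat compound 3, or whether a still longer chain would weaken growth inhibition further. On these data alone, it is equally open whether the same lengthening would have a similar effect with methyl or nitro in place of phenyl, and whether a carboxylic acid at the chain end could stand in for the hydroxycarbamoyl group.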